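Carbamate and amide variants on a shared benzothiazole-free core

A few compounds are considered here, and "the series" means these few. Any claim that something is new, unique, unknown or untested is made for them only; others in the source may bear on it.

Measured compounds:
compound 1, `CCCC(=O)Nc1nc2ccc(NC(=O)c3c(Cl)cccc3Cl)cc2s1`: 0.01 ug/mL
compound 2, `CC(C)CC(=O)Nc1nc2ccc(NC(=O)c3c(Cl)cccc3Cl)cc2s1`: 0.012 ug/mL
compound 3, `CCOC(=O)Nc1nc2ccc(NC(=O)c3c(Cl)cccc3Cl)cc2s1`: 0.0026 ug/mL

All three were run in a functional assay on WI-38 VA13 cells (Homo sapiens) for cytotoxicity; a lower number here means that less compound is needed, a higher number that more compound is needed for the effect. Compound 1 and compound 2 share the same core and differ by methyl in place of hydrogen on a saturated chain carbon bound to two saturated chain carbons; this gave a 1.2-fold higher number from compound 1 to compound 2 (0.08 log units; within the scatter). Compound 3 carries a different group on the carbonyl carbon, the difference to compound 1 being (ethoxy in place of propyl on a carbonyl carbon). That exchange gave a 3.8-fold lower number from compound 1 to compound 3 (0.59 log units; beyond the scatter) and, against compound 2, a 4.6-fold lower number from compound 2 to compound 3 (0.66 log units; beyond the scatter). Compound 3 thus has the lowest number of the three, both steps to it lying beyond the scatter.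

Compound 4, `CCCOC(=O)Nc1nc2ccc(NC(=O)c3c(Cl)cccc3Cl)cc2s1`, is not yet measured. It differs from compound 3 by methyl in place of hydrogen on a saturated chain carbon, two bonds along the chain from an oxygen next to a carbonyl group. For the measured compounds named here, this is the same kind of change as the one from compound 1 to compound 2, the added methyl sitting in each case on a saturated chain carbon; in compound 2 that carbon is bound to two saturated chain carbons, in compound 4 it lies two bonds along the chain from an oxygen next to a carbonyl group. Going by the values given here, the only precedent, a 1.2-fold higher number from compound 1 to compound 2 (0.08 log units; within the scatter), sits within the scatter.

On that basis the step from compound 3 to compound 4 in this assay is expected to be a 1.2-fold higher number from compound 3 to compound 4 (0.06 log units; within the scatter), near nil. Compound 4 is therefore expected to give about 0.003 ug/mL, with a plausible range from 0.0013 ug/mL to 0.007 ug/mL. One precedent is a thin base, and the two places differ as stated, so the range is kept wide.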

Compound 4, half-maximal effective concentration: 0.0025 ug/mL
Estimate against measurement, compound 4: 1.2-fold (0.08 log units) above; low and high end bracket the measured number.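

The added methyl behaves alike on the two cores, the two steps agreeing within the scatter: the same change on two cores in this assay, a 1.2-fold higher number (0.08 log units; within the scatter) from compound 1 to compound 2 and a 1.0-fold lower number (0.02 log units; within the scatter) from compound 3 to compound 4, 1.2-fold (0.10 log units) apart, within the scatter of two such steps

With a 1.0-fold lower number from compound 3 to compound 4 (0.02 log units; within the scatter), what carries over in this assay is the absence of a readable effect, and it rests on a single pair of steps; it does not show that the same change would stay without effect on a further core or elsewhere on the chain. The larger exchange at the carbonyl carbon persists with the added methyl in place, since propoxy in place of propyl gives a 4.0-fold lower number from compound 1 to compound 4 (0.60 log units; beyond the scatter) and propoxy in place of isobutyl gives a 4.8-fold lower number from compound 2 to compound 4 (0.68 log units; beyond the scatter), both beyond the scatter and close in size to the ethoxy steps a 3.8-fold lower number from compound 1 to compound 3 (0.59 log units; beyond the scatter) and a 4.6-fold lower number from compound 2 to compound 3 (0.66 log units; beyond the scatter).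

The compounds shown leave open how far the chain on the oxygen can be changed before the number moves, for example with a butoxy chain or a branched isopropoxy group. Also open, as far as these compounds go, is whether an amine or a carboxylic acid at the end of that chain would keep the number near those of compound 3 and compound 4 in this assay.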